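A Ring Swap on the Ketone Side of Compound 1

The compounds below may be only part of what the source reports. "The series", "measured", "known", "first", "only" and "open" are said of these compounds alone.

Compound 1: `O=C(/C=C/c1ccc2c(c1)B(O)OC2)c1cccs1`
Compound 2: `O=C(/C=C/c1ccc2c(c1)B(O)OC2)c1ccc([N+](=O)[O-])cc1`

In a toxicity assay on MCF-10A cells (Homo sapiens) for cytotoxicity, read by MTT assay, with a stated time of 48 h (a higher number here means a weaker inhibitor, a lower number a stronger inhibitor), compound 1 gives 13800 nM, and compound 2 gives 17500 nM. Compound 1 holds the smaller of the two numbers, yet its gap to compound 2 lies within the usual scatter, so the two cannot be told apart. Among the measured compounds shown here, no step between measured compounds that differ in one place is available. Compound 3 `O=C(/C=C/c1ccc2c(c1)B(O)OC2)c1ccccc1O` differs from compound 1 in one place: 2-hydroxyphenyl in place of thiophen-2-yl on a carbonyl carbon. For the measured compounds named here, with no measured step of this kind to lean on, no shift beyond the scatter is expected in this assay; compound 3 is estimated at 14000 nM, between 5000 nM and 40000 nM. This amounts to an expected step of a 1.0-fold higher number from compound 1 to compound 3 (0.01 log units; within the scatter).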

Compound 3, half-maximal inhibitory concentration: 53700 nM
The estimate for compound 3 lay 3.8-fold (0.58 log units) below the measured number; the measured number lies above the stated range.
By their numbers in this assay, from the lowest: compounds 1 and 2 (each within the scatter of the next); then compound 3.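

In this assay, 2-hydroxyphenyl in place of thiophen-2-yl on the carbonyl carbon brings a 3.9-fold higher number from compound 1 to compound 3 (0.59 log units; beyond the scatter) and so shows that the number can move with the group at this position. Compound 2 also carries a six-membered aromatic ring here yet stays within the scatter of compound 1, so such a ring alone does not go with a shift of this size. The compounds shown leave open whether the hydroxyl group is what matters, and plain phenyl or 2-methoxyphenyl on the same carbon would test this. Nothing at hand explains the shift.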